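From 4-phenylphenyl to naphthalen-1-yl on a shared core

The compounds below may be only part of what the source reports. "The series", "measured", "known", "first", "only" and "open" are said of these compounds alone.

Of the compounds shown here, three built on a shared core have been tested in a functional assay on MCF7 cells (Homo sapiens) for antiproliferative activity, read by MTT assay, with a stated time of 72 h; on this read-out higher numbers stand for weaker inhibition and lower numbers for stronger inhibition. For compound 1 `COc1cc(/C=C/c2ccc(C3=C(c4ccc(O)cc4)C4CC(S(=O)(=O)Oc5ccc(Br)cc5)C3O4)cc2)cc(OC)c1`, the assay reports only a limit, > 100000 nM. Compound 2 `O=S(=O)(Oc1cccc(C(F)(F)F)c1)C1CC2OC1C(c1ccc(/C=C/c3cc(O)cc(O)c3)cc1)=C2c1ccc(O)cc1` gives 11500 nM, and compound 3 `O=S(=O)(Oc1ccc(-c2ccccc2)cc1)C1CC2OC1C(c1ccc(/C=C/c3cc(O)cc(O)c3)cc1)=C2c1ccc(O)cc1` gives 7800 nM. Going by the values given here, these are the only two true numbers available, and they lie within the scatter of each other, so compound 3 cannot be ranked apart from compound 2. The measured step is a 1.5-fold lower number from compound 2 to compound 3 (0.17 log units; within the scatter), with 4-phenylphenyl in place of 3-(trifluoromethyl)phenyl on an oxygen.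

Compound 4 `O=S(=O)(Oc1cccc2ccccc12)C1CC2OC1C(c1ccc(/C=C/c3cc(O)cc(O)c3)cc1)=C2c1ccc(O)cc1` keeps everything else in compound 3 and changes a single group, with naphthalen-1-yl in place of 4-phenylphenyl on an oxygen. Among the compounds with values here, no measured step links compound 1 to the others, so its limit gives no size for this change. Within the data shown here, the only measured exchange at this place is a 1.5-fold lower number from compound 2 to compound 3 (0.17 log units; within the scatter), and it stayed within the scatter. From the compounds shown here alone, on that single step, no change beyond the scatter is expected in this assay, and the direction remains open. The estimated step is a 1.2-fold higher number from compound 3 to compound 4 (0.06 log units; within the scatter). For compound 4 the estimated value is 9000 nM, with an expected range of 4000 nM to 22000 nM.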

Compound 4, half-maximal inhibitory concentration: 11000 nM
The estimate for compound 4 lay 1.2-fold (0.09 log units) below the measured number, within the range that was stated.
By their numbers in this assay, from the lowest: compounds 3, 4 and 2 (each within the scatter of the next). At a limit, above all of these: compound 1.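

In this assay, a third group on the oxygen whose other neighbour is the sulfonyl sulfur gives no separation: the exchange to naphthalen-1-yl is a 1.4-fold higher number from compound 3 to compound 4 (0.15 log units; within the scatter) and the exchange from 3-(trifluoromethyl)phenyl is a 1.0-fold lower number from compound 2 to compound 4 (0.02 log units; within the scatter) with both steps inside the scatter. Where the earlier compounds offered one comparison at this position, compounds 2, 3 and 4 now form a set of three groups with no pair told apart, and this holds even though 4-phenylphenyl and naphthalen-1-yl differ in heavy atoms while sharing two six-membered aromatic rings of carbon only. Nothing measured here explains why these three values sit so close together.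

From the compounds shown here alone, whether an amine, a carboxylic acid or a longer chain on this oxygen would move the number beyond the scatter remains open. Compound 1 gives > 100000 nM which is a limit and not a number, and it differs from compounds 2, 3 and 4 in more than one place, so it says nothing about this position.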